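The compounds below may be only part of what the source reports. "The series", "measured", "known", "first", "only" and "open" are said of these compounds alone.

Measured in a functional assay on MCF7 cells (Homo sapiens) for antiproliferative activity, read by MTT assay, with a stated time of 72 h; on this read-out lower numbers stand for stronger inhibition and higher numbers for weaker inhibition:
Compound 1 `CCN(CC)CCCOc1cc2ncnc(Nc3ccc(C#N)cc3)c2cc1OC`: > 100000 nM
Compound 2 `COc1cc2c(Nc3ccc(C#N)cc3)ncnc2cc1OCCCN1CCC(C)CC1`: 43100 nM

The entry for compound 1 is a limit of the assay and not a number. Among the measured compounds shown here, compound 2 therefore holds the only number in this assay. Compound 3 `COc1cc2c(Nc3ccc(C#N)cc3)ncnc2cc1OCCCN1CCC(CO)CC1` follows from compound 2 through (hydroxy in place of hydrogen on a saturated chain carbon bound to a saturated ring carbon), which turns methyl into hydroxymethyl. For the measured compounds named here, the one measured step nearby is an at least 2.3-fold lower number from compound 1 to compound 2 (0.36 log units; beyond the scatter), which put 4-methylpiperidin-1-yl in place of diethylamino and starts from the limit of > 100000 nM in this assay, at which 1 of the 2 values shown sits. It did not test hydroxy, so it gives no firm guide to size or direction. The expected step of a 1.0-fold higher number from compound 2 to compound 3 (0.02 log units; within the scatter) is none beyond the scatter. Compound 3 is estimated at 45000 nM, within a range of 15000 nM to 100000 nM.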

Compound 3, half-maximal inhibitory concentration: 35100 nM
Compound 3: middle estimate off by 1.3-fold (0.11 log units), on the high side, and the stated range covers the measured number.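

In this assay, hydroxy in place of hydrogen on a saturated chain carbon bound to a saturated ring carbon gives a 1.2-fold lower number from compound 2 to compound 3 (0.09 log units; within the scatter) and so leaves compound 2 and compound 3 indistinguishable. Replacing diethylamino with 4-(hydroxymethyl)piperidin-1-yl gives an at least 2.8-fold lower number from compound 1 to compound 3 (0.45 log units; beyond the scatter), much as the 4-methylpiperidin-1-yl group did. From the compounds shown here alone, the entry for compound 1 is a limit and not a number, so the size of this step stays open: the limit of > 100000 nM in this assay, at which 1 of the 3 values shown sits.

Going by these compounds, it remains open whether a carboxylic acid or an amine in place of the hydroxy, or a longer chain carrying it, would shift the number beyond the scatter.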